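A few compounds are considered here, and "the series" means these few. Any claim that something is new, unique, unknown or untested is made for them only; others in the source may bear on it.

Two compounds built on one shared core have been run through a functional assay on MCF7 cells (Homo sapiens) for cytotoxicity, read by MTT assay, with a stated time of 96 h; a higher number here means a weaker inhibitor, a lower number a stronger inhibitor. Compound 1, `Cc1c(CO)cc2n1[C@@H](c1ccccc1)SC2`, gives 1900 nM in this assay. Compound 2, `Cc1cc(CO)c2n1[C@@H](c1ccccc1)SC2`, gives 19900 nM in this assay and so stands at the weaker end of the two numbers, its gap to compound 1 lying beyond the scatter. Compound 3, `Cc1c(CO)c(CO)c2n1[C@@H](c1ccccc1)SC2`, has not yet been measured; it differs from compound 2 by hydroxymethyl in place of hydrogen on an aromatic carbon. Compound 3 is expected to give 4000 nM in this assay, within a range from 1000 nM to 16000 nM. The expected step is a 5.0-fold lower number from compound 2 to compound 3 (0.70 log units; beyond the scatter), a gain in potency beyond the scatter.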

Compound 3, half-maximal inhibitory concentration: 600 nM
Compound 3: middle estimate off by 6.7-fold (0.82 log units), on the high side; the measured number lies below the stated range.
By their numbers in this assay, from the lowest: compound 3; then compound 1; then compound 2.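

In this assay, hydroxymethyl in place of hydrogen on an aromatic carbon brings a large gain, a 33-fold lower number from compound 2 to compound 3 (1.52 log units; beyond the scatter), so this position accepts the group and compound 2's weak number is not fixed by the shared core. The same kind of change gives a modest gain, a 3.2-fold lower number from compound 1 to compound 3 (0.50 log units; beyond the scatter), so the two hydroxymethyl groups together outdo either one alone. No evidence here accounts for these gains. Going by these compounds, whether an amine, a carboxylic acid or a longer chain at this position would do as well remains open.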